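Swapping an aromatic ring on a shared core: cytotoxicity expected

The source may report more compounds than this note shows. Statements on the series, on what has been measured and on what is new or still open speak of the compounds shown alone.

Three compounds measured in an ADME assay on Huh-7 cells (Homo sapiens) for cytotoxicity, read by MTT assay, with a stated time of 48 h (on this read-out lower numbers stand for higher toxicity in this test and higher numbers for lower toxicity in this test), share a common core and differ in their side groups. Compound 1 `CN(C)CCCCN(C(=O)O)c1ccccc1Cn1nc(-c2ccc(F)cc2)c2ccccc2c1=O` gives 48500 nM. Compound 2 `CC(c1ccc(N(CCCCN(C)C)C(=O)O)cc1)n1nc(-c2ccc(F)cc2)c2ccccc2c1=O` gives 15200 nM. Compound 3 `CN(C)CCCCOC(=O)Nc1ccc(Cn2nc(-c3ccncc3)c3ccccc3c2=O)cc1` gives 62700 nM, the highest of the three numbers; the number for compound 1 sits within the usual scatter of it, whereas the number for compound 2 lies clearly beyond that scatter.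

Compound 4 `COc1cccc(-c2nn(Cc3ccc(NC(=O)OCCCCN(C)C)cc3)c(=O)c3ccccc23)c1` has not yet been measured. It differs from compound 3 in one place only: 3-methoxyphenyl in place of pyridin-4-yl on an aromatic carbon. Within the data shown here, no pair among the measured compounds isolates this particular change, so there is no directly comparable step to lean on. The three measured numbers all fall in a fairly narrow band, and an aromatic ring exchanged for another aromatic ring of similar size is a modest alteration. The expectation is therefore a step of a 1.4-fold lower number from compound 3 to compound 4 (0.14 log units; within the scatter), that is, no change beyond the scatter, with a slight lean toward a lower number.

On that basis compound 4 is estimated to give 45000 nM in this assay, within a range from 20000 nM to 100000 nM.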

Compound 4, half-maximal cytotoxic concentration: 17600 nM
The estimate for compound 4 lay 2.6-fold (0.41 log units) above the measured number; measured number below the stated range.
By their numbers in this assay, from the lowest: compounds 2 and 4 (each within the scatter of the next); then compounds 1 and 3 (each within the scatter of the next).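

Exchanging pyridin-4-yl for 3-methoxyphenyl on the aromatic carbon next to the ring nitrogen is the first change shown that isolates this position, and in this assay it gives a 3.6-fold lower number from compound 3 to compound 4 (0.55 log units; beyond the scatter) with the step lying beyond the usual scatter. The position is therefore not indifferent to which six-membered aromatic ring it carries: a lower number here stands for higher toxicity in this test, even though the two groups match in hydrogen-bond donors, hydrogen-bond acceptors and net charge. No measurement at hand bears on what lies behind this step.

The change removes the ring nitrogen and adds a methoxy group in a single move, so these compounds cannot say which of the two accounts for the lower number, and a plain phenyl ring at this position would separate them. Also open, going by these compounds, is whether an amine or a carboxylic acid on that ring would shift the number further, and whether the step would hold with a different chain on the other side of the shared core.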